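The source may report more compounds than this note shows. Statements on the series, on what has been measured and on what is new or still open speak of the compounds shown alone.

Measured compounds in a functional assay on CCRF-CEM cells (Homo sapiens) for cytotoxicity, read by MTT assay, with a stated time of 72 h; on this read-out lower numbers stand for stronger inhibition of growth and higher numbers for weaker inhibition of growth:
- compound 1 `COc1ccc(OC(=O)Nc2ccc([Se]C#N)cc2)cc1`: 41500 nM
- compound 2 `CCCCCCOC(=O)Nc1ccc([Se]C#N)cc1`: 46200 nM
- compound 3 `N#C[Se]c1ccc(NC(=O)Oc2ccc(F)cc2)cc1`: 41900 nM

Compound 3 stands second highest of the three numbers, yet all three lie within the scatter of one another. Compound 4 `Cc1ccc(OC(=O)Nc2ccc([Se]C#N)cc2)cc1` differs from compound 3 by methyl in place of fluoro on an aromatic carbon. For the measured compounds named here, only one measured step bears on this position, and it was flat: a 1.0-fold higher number from compound 1 to compound 3 (0.00 log units; within the scatter). A methyl entering in place of fluoro has no precedent among these compounds, but since exchanging the para group earlier moved nothing, no step beyond the scatter is expected for compound 4 in this assay; the expected step is a 1.0-fold higher number from compound 3 to compound 4 (0.00 log units; within the scatter). Compound 4 is estimated at 42000 nM, with a range from 21000 nM to 84000 nM.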

Compound 4, concentration for total growth inhibition: 44700 nM
Compound 4: the middle estimate sits 1.1-fold (0.03 log units) below what was measured, and the stated range covers the measured number.
By their numbers in this assay, from the lowest: compounds 1, 3, 4 and 2 (each within the scatter of the next).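

In this assay methyl now joins fluoro and methoxy at this place on the aromatic ring, and neither new step leaves the scatter (a 1.1-fold higher number from compound 3 to compound 4 (0.03 log units; within the scatter); a 1.1-fold higher number from compound 1 to compound 4 (0.03 log units; within the scatter)). Three different groups at this one position therefore give the same reading within the scatter, where earlier only two could be compared. Nothing measured here explains this flat result.

As far as these compounds go, whether an amine, a carboxylic acid or a longer chain at this position would move the number beyond the scatter remains open. So does whether this flat result would hold in other cell lines.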